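Fluoro on the methanesulfonamidophenyl ring: compound 1 to compound 4

The source may report more compounds than this note shows. Statements on the series, on what has been measured and on what is new or still open speak of the compounds shown alone.

Measured so far:
compound 1 `Cc1ccc(CC(CNC(=O)C2(c3ccc(NS(C)(=O)=O)cc3)CC2)COC(=O)C(C)(C)C)cc1C`, 396 nM
compound 2 `Cc1ccc(CC(CNC(=O)C(C)(C)c2ccc(NS(C)(=O)=O)cc2)COC(=O)C(C)(C)C)cc1C`, 370 nM
compound 3 `CC(C(=O)NCC(COC(=O)C(C)(C)C)Cc1ccc(C(C)(C)C)cc1)c1ccc(NS(C)(=O)=O)cc1`, 55 nM

In an assay on CHO cells for displacement of a labelled ligand from transient receptor potential cation channel subfamily V member 1 (Rattus norvegicus) (on this read-out lower numbers stand for stronger inhibition and higher numbers for weaker inhibition), compound 1 gives the highest of the three numbers. Compound 2 sits within the scatter of compound 1; compound 3 lies beyond it, with the lower number of the set. The unmeasured compound 4 `Cc1ccc(CC(CNC(=O)C2(c3ccc(NS(C)(=O)=O)c(F)c3)CC2)COC(=O)C(C)(C)C)cc1C` differs from compound 1 in one place: fluoro in place of hydrogen on an aromatic carbon, on an aromatic carbon ortho to a methanesulfonamido group. Within the data shown here, no measured pair shows this change, so its size is unknown here. A step from compound 1 to compound 4 of a 1.3-fold lower number from compound 1 to compound 4 (0.12 log units; within the scatter) is expected in this assay, no larger than the scatter, with the direction left open. Compound 4 is thus estimated at 300 nM, range 110 nM to 800 nM.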

Compound 4, inhibition constant: 1580 nM
The estimate for compound 4 lay 5.3-fold (0.72 log units) below the measured number; measured number outside the range, above it.
By their numbers in this assay, from the lowest: compound 3; then compounds 2 and 1 (each within the scatter of the next); then compound 4.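

Replacing hydrogen with fluoro on the aromatic carbon ortho to a methanesulfonamido group gives a 4.0-fold higher number from compound 1 to compound 4 (0.60 log units; beyond the scatter) in this assay on the core of compound 1, which moves towards weaker inhibition. Among these compounds, the earlier compounds all carry hydrogen on this carbon, so this is the first reading of any change at this position. Nothing available explains the step.

Going by these compounds, whether chloro, methyl or methoxy on the same carbon gives a step of similar size remains open. Also open, on these data alone, is whether the fluoro step carries over to the core of compound 3 in this assay or to that of compound 2.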